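The source may report more compounds than this note shows. Statements on the series, on what has been measured and on what is new or still open speak of the compounds shown alone.

Compound 3 `CC(C)=CCc1cc(C(=O)Nc2cc3ccc(OCCCNCC(N)=O)c(C)c3oc2=O)ccc1O` gives 1460 nM in a functional assay on MCF7 cells (Homo sapiens) for antiproliferative activity; a lower number here means a stronger inhibitor, a higher number a weaker inhibitor. Among the three measured compounds it stands second highest: compound 1 `CC(C)=CCc1cc(C(=O)Nc2cc3ccc(OCCCNC(C)(C)C)c(C)c3oc2=O)ccc1O` gives 950 nM, and compound 2 `COC(=O)CNCCCOc1ccc2cc(NC(=O)c3ccc(O)c(CC=C(C)C)c3)c(=O)oc2c1C` gives 2820 nM; the step of a 1.5-fold higher number from compound 1 to compound 3 (0.19 log units; within the scatter) and the step of a 1.9-fold lower number from compound 2 to compound 3 (0.29 log units; within the scatter) both lie within the scatter. Compound 4 `CC(C)=CCc1cc(C(=O)Nc2cc3ccc(OCCCN(C)Cc4ccccc4)c(C)c3oc2=O)ccc1O` differs from compound 3 by a single change: benzyl(methyl)amino in place of (carbamoylmethyl)amino on a saturated chain carbon, three bonds along the chain from an oxygen on an aromatic ring. All three measured steps alter the substituent on this same amine nitrogen: a 3.0-fold higher number from compound 1 to compound 2 (0.47 log units; beyond the scatter), a 1.5-fold higher number from compound 1 to compound 3 (0.19 log units; within the scatter) and a 1.9-fold lower number from compound 2 to compound 3 (0.29 log units; within the scatter). Among the compounds with values here, of these only the step to (methoxycarbonyl)methyl moved the number beyond the scatter, and it went toward a weaker inhibitor. Within the data shown here, none of them introduces an aromatic ring at this position, so the change to compound 4 has no direct precedent among the measured compounds. Compound 4 is therefore expected to give a number in this assay close to that of compound 3, with the step of a 1.3-fold lower number from compound 3 to compound 4 (0.12 log units; within the scatter) expected to remain within the scatter. The estimate for compound 4 in this assay is 1100 nM, with a range from 400 nM to 3000 nM.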

Compound 4, half-maximal inhibitory concentration: 11500 nM
For compound 4 the middle estimate is 10-fold (1.02 log units) below the measured one, and the stated range ends below it.
By their numbers in this assay, from the lowest: compounds 1, 3 and 2 (each within the scatter of the next, the first and the last beyond it); then compound 4.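

In this assay, benzyl(methyl)amino separates compound 4 from all three earlier compounds, and every step is beyond the scatter (a 7.9-fold higher number from compound 3 to compound 4 (0.90 log units; beyond the scatter)) (a 4.1-fold higher number from compound 2 to compound 4 (0.61 log units; beyond the scatter)) (a 12-fold higher number from compound 1 to compound 4 (1.08 log units; beyond the scatter)). The earlier changes on this amine nitrogen gave smaller steps, so this position tolerates less than they suggested, and compound 4, the only one here with an aromatic ring on this nitrogen, is the weakest inhibitor of the four. Nothing available explains this loss of activity.

Compound 4 gains both a benzyl and a methyl on the nitrogen, so the compounds shown cannot assign the loss to either one. Benzylamino, which lacks the methyl, and dimethylamino, which lacks the ring, would separate the two.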